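Substituting the aryl group: compound 3 to compound 4

The source may report more compounds than this note shows. Statements on the series, on what has been measured and on what is new or still open speak of the compounds shown alone.

Compound 3 `OC(CCN1CC=C(Cc2ccccc2)CC1)c1ccc(Cl)cc1` gives 61% in an assay on CHO cells for inhibition of sodium-dependent dopamine transporter (Homo sapiens), read by scintillation counting, with a stated time of 10 min, tested at 10 uM (on this read-out lower numbers stand for less inhibition and higher numbers for more inhibition at the one concentration tested (going by the name of the read-out)), the highest of the three numbers in hand. Compound 1 `OC(CCN1CC=C(Cc2ccccc2)CC1)c1cccs1` gives 52%, and the step of a number 9 percentage points higher from compound 1 to compound 3 (within the scatter) stays within the scatter. Compound 2 `Cc1ccc(C(O)CCN2CC=C(Cc3ccccc3)CC2)cc1` gives 30%; the step of a number 31 percentage points higher from compound 2 to compound 3 (beyond the scatter) is the large one in this set, and the step of a number 22 percentage points lower from compound 1 to compound 2 (beyond the scatter) points the same way.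

Compound 4 `OC(CCN1CC=C(Cc2ccccc2)CC1)c1ccc(F)cc1F` differs from compound 3 as follows: 2,4-difluorophenyl in place of 4-chlorophenyl on a saturated chain carbon bound to an oxygen on a saturated carbon and a saturated chain carbon. Among the measured compounds shown here, no measured step exchanges one halogen-bearing aryl for another, so the only bearing on it is indirect: compound 3 and compound 1 sit close, while compound 2 stands apart. A halogen-bearing aryl stays in place, so a step of no more than modest size is expected, with the direction uncertain; the estimate is a number 11 percentage points lower from compound 3 to compound 4 (beyond the scatter). Compound 4 is expected to give 50%, within a range from 30% to 70%.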

Compound 4, a percentage reported as inhibition, at one concentration (the size of the read-out at that concentration, not a potency): 66%
Compound 4: the middle estimate sits 16 percentage points below what was measured; low and high end bracket the measured number.
By their numbers in this assay, from the lowest: compound 2; then compounds 1, 3 and 4 (each within the scatter of the next, the first and the last beyond it).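

In this assay, this saturated chain carbon accepts 2,4-difluorophenyl in place of 4-chlorophenyl with no step beyond the scatter (a number 5 percentage points higher from compound 3 to compound 4 (within the scatter)), so the high level seen with one halogen-bearing aryl also holds with a second, differently substituted one. The gap to the 4-methylphenyl group stays large (a number 36 percentage points higher from compound 2 to compound 4 (beyond the scatter)), while thiophen-2-yl, which compound 3 could not be told apart from, now falls behind by a step beyond the scatter (a number 14 percentage points higher from compound 1 to compound 4 (beyond the scatter)). No measured evidence accounts for these differences.

Open, from the compounds shown here alone, is whether one fluoro group alone holds this level, as a 4-fluorophenyl group at the same place would show. Also open, going by these compounds, is how a 4-methoxyphenyl or pyridyl group would read here, and whether the level survives an amine in place of the hydroxyl group.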